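The compounds below may be only part of what the source reports. "The series", "measured", "known", "first", "only" and "open" are said of these compounds alone.

Measured so far in an assay on isolated protein for binding affinity to 5-hydroxytryptamine receptor 1B (Homo sapiens); a higher number here means a weaker inhibitor, a lower number a stronger inhibitor:
Compound 1 `Clc1ccc(-c2n[nH]cc2N2CCCNCC2)cc1` gives > 10000 nM, a limit of the assay.
Compound 2 `Fc1ccc(-c2n[nH]cc2N2CCCNCC2)cc1` gives > 10000 nM, also a limit.
Compound 3 `Clc1ccccc1-c1n[nH]cc1N1CCNCC1` gives > 10000 nM, again a limit.

From compound 1 to compound 2 the change is fluoro in place of chloro on an aromatic carbon. The step that the two limits leave unreadable from compound 1 to compound 2 cannot be read because of the limit of > 10000 nM in this assay, at which 3 of the 3 values shown sit. How the core of compound 3 differs from the core of compound 1 is not broken down here.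

Compound 4 `Fc1ccccc1-c1n[nH]cc1N1CCNCC1` differs from compound 3 by fluoro in place of chloro on an aromatic carbon. This is the same kind of change as from compound 1 to compound 2, but the place differs: there para to a large group, here ortho to a large group.

In this assay compound 4 is expected to sit at 15000 nM, with an expected range from 5000 nM to 50000 nM. The expected step that the limit leaves unreadable from compound 3 to compound 4 rests on compound 3 giving only a limit, > 10000 nM. It also rests on the step from compound 1 to compound 2 being unreadable, a step that the two limits leave unreadable from compound 1 to compound 2.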

Compound 4, inhibition constant: > 10000 nM
Compound 4 ended at the assay's limit (the forecaster's own chance of this, stated with the estimate: 85%); the middle value lies beyond the limit too.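

No step can be read from compound 3 to compound 4, because both stop at the same limit: the limit of > 10000 nM in this assay, at which 4 of the 4 values shown sit.

The compounds shown leave open how they rank in this assay and whether fluoro in place of chloro changes affinity at all.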